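Removing a benzyl group from an indazole-type core

A few compounds are considered here, and "the series" means these few. Any claim that something is new, unique, unknown or untested is made for them only; others in the source may bear on it.

Measured compounds:
- compound 1, `COc1ccc(Cn2nc(-c3ccccc3)c3cc(C(=N)Nc4cccc(C(F)(F)F)c4)nc(NC4CCCCC4)c32)cc1`, "not determined" (no result reported)
- compound 2, `COc1cc(Nc2nc(C(=N)Nc3ccccc3)cc3c(-c4ccccc4)n[nH]c23)cc(OC)c1OC`, 3900 nM
- compound 3, `COc1ccc(Cn2nc(-c3ccccc3)c3cc(C(=N)Nc4cccc(C(F)(F)F)c4)nc(Nc4cc(OC)c(OC)c(OC)c4)c32)cc1`, "not determined" (no result reported)

All three compounds were examined in a functional assay on HT-1080 cells (Homo sapiens) for cytotoxicity, read by MTT assay, with a stated time of 72 h (on this read-out higher numbers stand for weaker inhibition and lower numbers for stronger inhibition), a test of how strongly each one stops tumor cells from growing. Only compound 2 returned a number: in this assay compound 2 gives 3900 nM. Compound 3 has no number at all in this assay, and compound 1 is a further entry without one, so compound 3 cannot be placed in any order among the measured compounds.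

Compound 4, `COc1cc(Nc2nc(C(=N)Nc3cccc(C(F)(F)F)c3)cc3c(-c4ccccc4)n[nH]c23)cc(OC)c1OC`, is the compound not yet measured. It arises from compound 3 by one change: hydrogen in place of 4-methoxybenzyl on an aromatic nitrogen. Among the measured compounds shown here, no pair of measured compounds shows a step of this kind, so its size and direction in this assay cannot be read from the data; it may well lie within the scatter, or in either direction beyond it.

For the measured compounds named here, the only anchor is compound 2 with its value of 3900 nM in this assay. Compound 4 is therefore estimated to fall near that figure, at 3000 nM, with a range from 800 nM to 12000 nM.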

Compound 4, half-maximal inhibitory concentration: 6700 nM
For compound 4 the middle estimate is 2.2-fold (0.35 log units) below the measured one, within the range that was stated.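

Among the compounds shown here, compound 4 gives the first comparison, and it concerns the aromatic carbon that carries trifluoromethyl rather than the ring nitrogen: in this assay, trifluoromethyl in place of hydrogen gives a 1.7-fold higher number from compound 2 to compound 4 (0.24 log units; within the scatter), so compound 2 and compound 4 cannot be told apart in this assay. Compound 3 has no number, so the exchange of 4-methoxybenzyl for hydrogen on the aromatic nitrogen cannot be read, and this result says nothing about that change. No supporting measurement bears on this result.

Going by these compounds, whether an amine or a carboxylic acid on that same aromatic carbon would move the value beyond the scatter remains open. Also open, on these data alone, is whether a methyl or ethyl group on the aromatic nitrogen would give a value different from that of compound 4.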